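Ethyl for oxan-4-yl on an aromatic nitrogen

The compounds below may be only part of what the source reports. "The series", "measured", "known", "first", "only" and "open" are said of these compounds alone.

In a physicochemical assay for lipophilicity, using the shake flask method, measured as octanol-water partition, at pH 7.4 (on this read-out lower numbers stand for lower lipophilicity and higher numbers for higher lipophilicity), compound 1 (`CC(C)n1cc(-c2ccnc3[nH]c(C4CCN(CC(=O)N(C)C)CC4)cc23)cnc1=O`) gives 0.4 and compound 3 (`CC(C)n1cc(-c2ccnc3[nH]c(C4CCN(CC(=O)N5CCCCC5)CC4)cc23)ccc1=O`) gives 2.8 on the same scale. Compound 2 (`CN(C)C(=O)CN1CCC(c2cc3c(-c4ccc(=O)n(C5CCOCC5)c4)ccnc3[nH]2)CC1`) at 1.1 stands between them, second highest of the three, with both gaps beyond the scatter. Compound 4 (`CCn1cc(-c2ccnc3[nH]c(C4CCN(CC(=O)N(C)C)CC4)cc23)ccc1=O`) has not yet been measured. Going from compound 2 to compound 4, the structure changes (ethyl in place of oxan-4-yl on an aromatic nitrogen) with ethyl in place of oxan-4-yl on an aromatic nitrogen. For the measured compounds named here, no measured pair shows this change alone, so the expectation is tentative: in this assay no step beyond the scatter is expected, in either direction. The expected step (a number 0.10 log units higher from compound 2 to compound 4 (within the scatter)) is small. Compound 4 is estimated at 1.2 with an expected range of 0.7 to 1.7 for the measurement.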

Compound 4, distribution coefficient: 1.2
Compound 4: the middle estimate sits on the measured number at the digits printed; low and high end bracket the measured number.
By their numbers in this assay, from the lowest: compound 1; then compounds 2 and 4 (each within the scatter of the next); then compound 3.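

In this assay, ethyl in place of oxan-4-yl on an aromatic nitrogen gives a number 0.10 log units higher from compound 2 to compound 4 (within the scatter), so at this position, on this core, removing the six-membered non-aromatic ring leaves the two compounds indistinguishable. The group on the aromatic carbon separates compounds more clearly: a number 0.80 log units higher from compound 1 to compound 4 (beyond the scatter) accompanies a group of 9 heavy atoms, with 1 ring hetero atom, in place of a group of 10 heavy atoms, with 2. As far as these compounds go, whether an amine or a longer chain on that aromatic nitrogen would also stay within the scatter of compound 2 remains open. The compounds shown come with no evidence that bears on the cause of either step.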